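Pyrimidinyl sulfonamides: half-life after a pyrazole swap

This account rests on a few compounds, and the source may have more. Where it says the series, first, only, none or still open, it means among the compounds named here.

Measured so far:
- compound 1 `Cn1nccc1-c1cc(C(F)(F)F)ccc1[C@H]1CCc2cc(S(=O)(=O)Nc3ncccn3)ccc21`: 2.7 h
- compound 2 `O=S(=O)(Nc1ncccn1)c1ccc2c(c1)OCC[C@@H]2c1ccc(C(F)(F)F)cc1-c1ccc(F)nc1`: 9.8 h

Two compounds have numbers in an ADME assay on the whole organism (Rattus norvegicus, strain Sprague-Dawley) for metabolic stability, read by LC-MS, with a stated time of 24 h, at a dose of 1 mg/kg by the intravenous route; a lower number here means that the compound disappears faster, a higher number that the compound lasts longer. Compound 2 stands highest of the two; the nearest is compound 1, with a number that is lower by more than the scatter allows. Compound 1 carries 1-methyl-1H-pyrazol-5-yl and a different core, so its value says nothing clean about either part on its own.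

Compound 3 `Cn1nccc1-c1cc(C(F)(F)F)ccc1[C@H]1CCOc2cc(S(=O)(=O)Nc3ncccn3)ccc21` is the next member and has not yet been measured in this assay. It differs from compound 2 in one place: 1-methyl-1H-pyrazol-5-yl in place of 6-fluoropyridin-3-yl on an aromatic carbon. Within the data shown here, no pair of measured compounds shows this change by itself, so there is no directly comparable step on record.

Expectation: with the same 1-methyl-1H-pyrazol-5-yl as compound 1, whose half-life in this assay is 2.7 h, a step from compound 2 downward is expected, of moderate size, a 2.0-fold lower number from compound 2 to compound 3 (0.29 log units; within the scatter). For compound 3 the estimated half-life in this assay is 5 h, within a range of 2.5 h to 11 h; a number no different from compound 2 beyond the scatter would not surprise.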

Compound 3, half-life: 4.2 h
Compound 3: middle estimate off by 1.2-fold (0.08 log units), on the high side; low and high end bracket the measured number.
By their numbers in this assay, from the lowest: compounds 1 and 3 (each within the scatter of the next); then compound 2.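

Among these compounds, with the core held constant, 1-methyl-1H-pyrazol-5-yl in place of 6-fluoropyridin-3-yl on this aromatic carbon, ortho to a large group and meta to a trifluoromethyl group, gives a 2.3-fold lower number from compound 2 to compound 3 (0.37 log units; beyond the scatter) in this assay as a modest step, and this is the first reading of the change free of any difference in the core. Compound 1 at 2.7 h and compound 3 at 4.2 h carry the same 1-methyl-1H-pyrazol-5-yl on different cores and lie within the scatter of each other, so this pair shows no separable core difference in half-life. No measurement at hand accounts for the step at this position.

Whether the step holds on the core of compound 1 remains open, as 6-fluoropyridin-3-yl is shown only on the core of compound 2. Also open is how a dimethylamino group or a carboxylic acid on this aromatic carbon would read in this assay against the two aromatic rings shown here.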